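The source may report more compounds than this note shows. Statements on the series, on what has been measured and on what is new or still open speak of the compounds shown alone.

Of the compounds shown here, three that share one core have been measured in an assay for inhibition of Indoleamine 2,3-dioxygenase 1 (Homo sapiens), read by spectrophotometry, with stated times of 1 h and 4 h; on this read-out lower numbers stand for stronger inhibition and higher numbers for weaker inhibition. Compound 1 `CC(=O)Nc1ccc(S(=O)(=O)NNc2ccc(C)cc2)cc1` gives 51 nM in this assay. Compound 2 `COc1ccc(NNS(=O)(=O)c2ccc(NC(C)=O)cc2)cc1` gives 254 nM in this assay, and compound 3 `CC(=O)Nc1ccc(S(=O)(=O)NNc2ccc(F)cc2)cc1` gives 79 nM in this assay. Among these three numbers compound 3 stands second highest; it sits within the usual scatter of compound 1, because a 1.5-fold higher number from compound 1 to compound 3 (0.19 log units; within the scatter), and clearly apart only from compound 2, because a 3.2-fold lower number from compound 2 to compound 3 (0.51 log units; beyond the scatter).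

Compound 4 `CC(=O)Nc1ccc(S(=O)(=O)NNc2ccc(Cl)cc2)cc1` differs from compound 3 in a single place: chloro in place of fluoro on an aromatic carbon, on an aromatic carbon of a six-membered aromatic ring of carbon only, para to a large group. For the measured compounds named here, no measured step exchanges one halogen for another, so the nearest guidance comes from the other changes made at this same spot. Going by the values given here, replacing methyl with fluoro, a 1.5-fold higher number from compound 1 to compound 3 (0.19 log units; within the scatter), stayed within the scatter, whereas putting methoxy there, a 5.0-fold higher number from compound 1 to compound 2 (0.70 log units; beyond the scatter), gave a modest loss of inhibition, and compound 2 is the one compound that falls away from the others. Two small groups at this spot gave close numbers, and chloro is likewise a single heavy atom. The step from compound 3 to compound 4 is therefore expected to be small, a 1.3-fold lower number from compound 3 to compound 4 (0.12 log units; within the scatter), with no direction beyond the scatter. Compound 4 is estimated at 60 nM in this assay, with a range from 25 nM to 150 nM.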

Compound 4, half-maximal inhibitory concentration: 155 nM
Compound 4: middle estimate off by 2.6-fold (0.41 log units), on the low side, and the stated range ends below it.
By their numbers in this assay, from the lowest: compounds 1, 3, 4 and 2 (each within the scatter of the next, the first and the last beyond it).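

Exchanging fluoro for chloro at this position gives a 2.0-fold higher number from compound 3 to compound 4 (0.29 log units; within the scatter) in this assay, so the two halogens cannot be told apart here, and chloro in place of methoxy, at a 1.6-fold lower number from compound 2 to compound 4 (0.21 log units; within the scatter) as well, means that compound 2 no longer stands clearly apart from every other compound. The new information comes from the comparison with methyl: chloro in its place gives a 3.0-fold higher number from compound 1 to compound 4 (0.48 log units; beyond the scatter) as a modest loss of inhibition, whereas fluoro in place of methyl stayed within the scatter, so a single heavy atom at this spot is no assurance of staying level with compound 1. No measurement at hand explains these steps.

On these data alone, it stays open how bromo, trifluoromethyl, a nitrile, an amine or a carboxylic acid would read at this same spot, and whether plain hydrogen there would fall nearer compound 1 or compound 2. As far as these compounds go, these four compounds also vary only this one place, so the effect of a change elsewhere on the shared core remains unknown.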